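A few compounds are considered here, and "the series" means these few. Any claim that something is new, unique, unknown or untested is made for them only; others in the source may bear on it.

Measured so far in a functional assay on LN-229 cells (Homo sapiens) for antiproliferative activity, with a stated time of 72 h; on this read-out lower numbers stand for stronger inhibition and higher numbers for weaker inhibition:

compound 1, `CCCCC#Cc1cc([C@@H]2O[C@H](CO)[C@@H](O)[C@H]2O)n2ncnc(N)c12`, gives 1000 nM
compound 2, `Nc1ncnn2c([C@@H]3O[C@H](CO)[C@@H](O)[C@H]3O)cc(C#Cc3cccs3)c12`, reaches only the limit > 100000 nM, a limit and not a number
compound 3, `Nc1ncnn2c([C@@H]3O[C@H](CO)[C@@H](O)[C@H]3O)cc(-c3ccc(Cl)cc3)c12`, gives 32600 nM

Compound 3 holds the highest of the two numbers that are real values; compound 1 lies below it, with a 33-fold higher number from compound 1 to compound 3 (1.51 log units; beyond the scatter). For compound 2 the value is a limit of this assay: the limit of > 100000 nM in this assay, at which 1 of the 3 values shown sits.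

Compound 4, `Nc1ncnn2c([C@@H]3O[C@H](CO)[C@@H](O)[C@H]3O)cc(/C=C/c3ccccc3)c12`, differs from compound 3 in one place: 2-phenylethenyl in place of 4-chlorophenyl on an aromatic carbon. For the measured compounds named here, two measured steps bear on this. Going from the hex-1-yn-1-yl of compound 1 to the 2-(thiophen-2-yl)ethynyl of compound 2 gave an at least 100-fold higher number from compound 1 to compound 2 (2.00 log units; beyond the scatter), and replacing that group by 4-chlorophenyl gave an at least 3.0-fold lower number from compound 2 to compound 3 (0.48 log units; beyond the scatter). A 2-phenylethenyl group, with its aromatic ring held on a two-carbon linker, sits between these two cases in shape, so a modest rise in the number is expected for compound 4, a 1.7-fold higher number from compound 3 to compound 4 (0.23 log units; within the scatter), with a fair chance that only a limit is reported. The estimate for compound 4 is 55000 nM, between 12000 nM and 150000 nM.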

Compound 4, half-maximal inhibitory concentration: 3900 nM
Estimate against measurement, compound 4: 14-fold (1.15 log units) above; measured number below the stated range.
By their numbers in this assay, from the lowest: compound 1; then compound 4; then compound 3. At a limit, above all of these: compound 2.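

In this assay, 2-phenylethenyl in place of 4-chlorophenyl gives an 8.4-fold lower number from compound 3 to compound 4 (0.92 log units; beyond the scatter), so carrying an aromatic ring does not by itself tie a group at this position to a weak result. The same group also compares well with 2-(thiophen-2-yl)ethynyl, which differs from it in both the linker and the ring, with an at least 25-fold lower number from compound 2 to compound 4 (1.40 log units; beyond the scatter), but this step rests on a value that is a limit and not a number: the limit of > 100000 nM in this assay, at which 1 of the 4 values shown sits. Even so, hex-1-yn-1-yl, a chain with no ring, keeps the lowest number of the set, with a 3.9-fold higher number from compound 1 to compound 4 (0.59 log units; beyond the scatter).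

On these data alone, whether the lower number of compound 4 goes with the double bond or with the loss of the chlorine stays open. Also open, as far as these compounds go, is how a saturated 2-phenylethyl group, or a longer chain ending in an amine, would behave at this position.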